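A few compounds are considered here, and "the series" means these few. Any claim that something is new, unique, unknown or untested is made for them only; others in the source may bear on it.

Series notes. Compound 1 `COc1ccc(-c2cc(-c3ccc4c(c3)CCCC4)nc3[nH]nc(N)c23)cc1OC` and compound 2 `CC(C)c1ccc(-c2cc(-c3ccc4c(c3)CCCC4)nc3[nH]nc(N)c23)cc1` share one core; compound 3 `CCOC(=O)COc1nc(-c2ccc3c(c2)CCCC3)cc(-c2ccc(OC)c(OC)c2)c1C#N` and compound 4 `CCOC(=O)COc1nc(-c2ccc3c(c2)CCCC3)cc(-c2ccc(C(C)C)cc2)c1C#N` share another, and the difference between the two cores is not broken down here. In an ADME assay on RAW264.7 cells (Mus musculus) for cytotoxicity, with a stated time of 24 h (a higher number here means a weaker inhibitor, a lower number a stronger inhibitor), compound 1 gives > 50000 nM, which is a limit of the assay and not a number. In this assay compound 2 gives > 50000 nM, again a limit rather than a number. The change 4-isopropylphenyl in place of 3,4-dimethoxyphenyl on an aromatic carbon thus gives a step that the two limits leave unreadable from compound 1 to compound 2. In this assay, for the measured compounds named here, compound 3 gives 26200 nM, the only number among the three values so far. The two remaining values sit at the limit of > 50000 nM in this assay, at which 2 of the 3 values shown sit.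

The same kind of change, (4-isopropylphenyl in place of 3,4-dimethoxyphenyl on an aromatic carbon), carries compound 3 to compound 4. The surroundings of the place differ: in compound 1 the aromatic carbon is part of a fused or bridged system of two rings, ortho to a fused ring and meta to a fused ring, whereas in compound 3 it is ortho to a cyano group and meta to a (ethoxycarbonyl)methoxy group. The step from compound 1 to compound 2 cannot be read, and it offers no size to set against the new pair. The step from compound 3 to compound 4 is expected near no change, at a 1.1-fold higher number from compound 3 to compound 4 (0.06 log units; within the scatter), with a wide range. Compound 4 is estimated at 30000 nM, between 12000 nM and 70000 nM, resting on compound 3 at 26200 nM.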

Compound 4, half-maximal inhibitory concentration: > 50000 nM
Compound 4 gave a limit, no number (the forecaster's own chance of this, stated with the estimate: 30%); middle value at least 1.6-fold (0.22 log units) from the limit.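

In this assay, 4-isopropylphenyl in place of 3,4-dimethoxyphenyl gives an at least 1.9-fold higher number from compound 3 to compound 4 (0.28 log units; that floor lies within the scatter), so on the core of compound 3 only a floor for the step can be read, and that floor does not separate the pair from no change. For the compounds shown here, the matching step on the core of compound 1 cannot be read, so the two cores offer no pair of sizes to compare, and these data show neither that the change carries across cores with the same size nor that it behaves differently on each. The only agreement is a weak one, that compound 2 and compound 4, the two compounds with 4-isopropylphenyl, both end at a limit rather than a number, and the reading of the series stops there: the limit of > 50000 nM in this assay, at which 3 of the 4 values shown sit.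

Open, on these data alone, is whether an amine or a carboxylic acid in place of the isopropyl group on the phenyl ring would bring either core to a number in this assay. Going by these compounds alone, also open is whether a longer chain in place of the (ethoxycarbonyl)methoxy group would shift the value of compound 3, which gives 26200 nM, the only number in the set.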